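Phenoxy to methoxy in a series of full agonists

A few compounds are considered here, and "the series" means these few. Any claim that something is new, unique, unknown or untested is made for them only; others in the source may bear on it.

compound 1 `Clc1ccncc1C1=CC2CNCC(C1)C2` 105%
compound 2 `C1=C(c2cccnc2)C[C@@H]2CNC[C@H]1C2` 139%
compound 3 `C1=C(c2cncc(Oc3ccccc3)c2)CC2CNCC1C2` 101%

In an in vitro functional assay on SH-SY5Y cells for agonist activity at Neuronal acetylcholine receptor; alpha3/beta4 (Homo sapiens), read by FLIPR and calcium flux (on this read-out higher numbers stand for larger maximal responses and lower numbers for smaller maximal responses), compound 1 gives 105%, compound 2 gives 139% and compound 3 gives 101%. Compound 3 has the lowest number of the three; it sits within the scatter of compound 1 and beyond the scatter below compound 2.

Compound 4 `COc1cncc(C2=CC3CNCC(C2)C3)c1` is the next candidate. The change from compound 3 is methyl in place of phenyl on an oxygen on an aromatic ring. Among the compounds with values here, no pair of measured compounds shows this change, so there is no measured step to lean on. With all three measured compounds reaching full response in this assay, the expected step from compound 3 to compound 4 is none beyond the scatter, a number 4 percentage points higher from compound 3 to compound 4 (within the scatter). Compound 4 is therefore expected to give about 105%, in the range 85% to 130%.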

Compound 4, largest response reached (reported as percent of maximum), in percent of the reference or control that the assay uses: 145%
Beside the measured number, compound 4's estimate is 40 percentage points below it; the whole stated range lies below it.
By their numbers in this assay, from the lowest: compounds 3 and 1 (each within the scatter of the next); then compounds 2 and 4 (each within the scatter of the next).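

Within the data shown here, on the oxygen on an aromatic ring, the choice of group clearly matters in this assay: phenoxy to methoxy gives a number 44 percentage points higher from compound 3 to compound 4 (beyond the scatter), a change the earlier compounds could not show. The maximal response at this position therefore depends on what the oxygen carries, and phenyl and methyl are not interchangeable there. Nothing measured here explains the size of this step.

As far as these compounds go, whether the response follows the size of the group on the oxygen remains open, and an ethoxy or benzyloxy group would test this. An amino group in place of methoxy would show whether the oxygen itself matters.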